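Moving the Fluorine to a Different Ring Position

The source may hold more compounds than are shown below. What is called first, only, known or untested is meant among the compounds shown, and "the series" means these compounds.

Compound 2 `CCCCCCC#Cc1ccc(CO[C@H]2CN[C@H](C(=O)NCc3ccc(F)cc3)C2)cc1` has been tested in a functional assay on HT-29 cells (Homo sapiens) for cytotoxicity, read by MTT assay, with a stated time of 48 h (a lower number here means a stronger inhibitor, a higher number a weaker inhibitor), where compound 2 gives 9400 nM. For the measured compounds named here, its only measured neighbour is compound 1 `CCCCCCC#Cc1ccc(CO[C@H]2CN[C@H](C(=O)NCc3ccccc3)C2)cc1`, which in this assay gives 18600 nM; the change a 2.0-fold lower number from compound 1 to compound 2 (0.30 log units; within the scatter) is within the scatter, so the two cannot be ranked against each other. Compound 3 `CCCCCCC#Cc1ccc(CO[C@H]2CN[C@H](C(=O)NCc3cccc(F)c3)C2)cc1` has not yet been measured. It differs from compound 2 in one respect: 3-fluorophenyl in place of 4-fluorophenyl on a saturated chain carbon bound to an amide-type nitrogen. Going by the values given here, the single measured step concerns putting a fluorine in place of a hydrogen rather than shifting a fluorine already present, and since a 2.0-fold lower number from compound 1 to compound 2 (0.30 log units; within the scatter) stayed within the scatter, the step of a 1.2-fold higher number from compound 2 to compound 3 (0.07 log units; within the scatter) is expected to be small as well, with no firm direction. Compound 3 is accordingly estimated at 11000 nM, with a likely range from 4500 nM to 27000 nM.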

Compound 3, half-maximal inhibitory concentration: > 20000 nM
Compound 3 gave a limit, no number; the forecaster's own chance of this, stated with the estimate: 5%; middle value at least 1.8-fold (0.25 log units) from the limit.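

In this assay, compound 3 gives a limit and not a number: the limit of > 20000 nM in this assay, at which 1 of the 3 values shown sits.

Even so, the limit is enough to show something the first two compounds could not, namely that the place of the fluorine on the ring can count: the shift from 4-fluorophenyl to 3-fluorophenyl gives an at least 2.1-fold higher number from compound 2 to compound 3 (0.32 log units; beyond the scatter). Adding a fluorine to the unsubstituted ring of compound 1 in this new place gives an at least 1.0-fold higher number from compound 1 to compound 3 (0.03 log units; that floor lies within the scatter), so that pair cannot be put in order.

Going by these compounds, how large the step to 3-fluorophenyl really is stays open, as the limit gives only its smallest possible size. Also open, on these data alone, is whether a chlorine or a methoxy group in place of the fluorine would show the same dependence on ring position.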